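The source may hold more compounds than are shown below. What is called first, only, known or untested is meant among the compounds shown, and "the series" means these compounds.

Measured in a functional assay (trachea) with Cavia porcellus as the target; a higher number here means that more compound is needed for the effect, a lower number that less compound is needed:
- Compound 1 `CCCn1c(=O)n(CCC#N)c(=O)c2[nH]cnc21`: 1700 nM
- Compound 2 `CCCn1c(=O)n(CCCOC)c(=O)c2[nH]cnc21`: 2900 nM

Within the data shown here, compound 2, at 2900 nM, lies within the scatter of compound 1, the only other compound measured. Compound 3 `CCCn1c(=O)n(CCC(C)=O)c(=O)c2[nH]cnc21` carries acetyl in place of methoxymethyl on a saturated chain carbon, two bonds along the chain from an aromatic nitrogen. Among the measured compounds shown here, only one measured step bears on this place, the swap of cyano for methoxymethyl, a 1.7-fold higher number from compound 1 to compound 2 (0.23 log units; within the scatter). On that single step, no change beyond the scatter is expected in this assay. The expected step is a 1.3-fold lower number from compound 2 to compound 3 (0.12 log units; within the scatter). Compound 3 is estimated at 2200 nM, with an expected range of 900 nM to 5500 nM.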

Compound 3, half-maximal effective concentration: 3500 nM
Compound 3: the middle estimate sits 1.6-fold (0.20 log units) below what was measured, within the range that was stated.
By their numbers in this assay, from the lowest: compounds 1, 2 and 3 (each within the scatter of the next, the first and the last beyond it).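

In this assay, acetyl in place of methoxymethyl on a saturated chain carbon, two bonds along the chain from an aromatic nitrogen, gives a 1.2-fold higher number from compound 2 to compound 3 (0.08 log units; within the scatter) and so does not separate the two groups. Acetyl in place of cyano gives a 2.1-fold higher number from compound 1 to compound 3 (0.31 log units; beyond the scatter) and is the only step at this place that passes the scatter, though modestly. No supporting measurement bears on these differences. Going by these compounds, whether an amine, a carboxylic acid or a longer chain at this place would give a larger step remains open.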